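The source may hold more compounds than are shown below. What is called first, only, known or untested is meant among the compounds shown, and "the series" means these compounds.

Compound 1 `CCOC(=O)c1nn(-c2ccccc2)c(-c2ccc(Br)cc2)c1CNC(C)(C)C`: 22000 nM; > 509000 nM (2 entries)
Compound 2 `CC(C)(C)NCc1c(C(=O)O)nn(-c2ccccc2)c1-c1ccc(Br)cc1`: > 585000 nM (a limit of the assay)
Compound 3 `COc1ccc(-c2c(CNC(C)(C)C)c(C(=O)O)nn2-c2ccccc2)cc1`: > 659000 nM (a limit of the assay)

In a functional assay on K562 cells (Homo sapiens) for inhibition, read by sulforhodamine B assay, with a stated time of 48 h (on this read-out lower numbers stand for stronger inhibition of growth and higher numbers for weaker inhibition of growth), compound 2 gives only a limit, > 585000 nM, and not a number. Compound 3 also stands at a limit, > 659000 nM. Compound 1 has mixed entries, (the several entries of compound 1 in this assay, 22000 nM; > 509000 nM (2 entries)). Within the data shown here, the only step among the measured compounds, a step that the two limits leave unreadable from compound 2 to compound 3, is therefore not readable in size or direction. Compound 4 `CC(C)(C)NCc1c(C(=O)O)nn(-c2ccc(Cl)cc2)c1-c1ccc(Br)cc1` differs from compound 2 by chloro in place of hydrogen on an aromatic carbon. Among the measured compounds shown here, no measured step bears on this change, so no size or direction beyond the scatter can be expected from the data. Compound 4 is estimated at 600000 nM, within 100000 nM to 1000000 nM, most likely again only a limit, which would mean an expected step that the limit leaves unreadable from compound 2 to compound 4 within the scatter.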

Compound 4, concentration for 50% growth inhibition: 297000 nM
The estimate for compound 4 lay 2.0-fold (0.31 log units) above the measured number, and the stated range covers the measured number.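

In this assay, changing phenyl to 4-chlorophenyl gives an at least 1.9-fold lower number from compound 2 to compound 4 (0.29 log units; that floor lies within the scatter). Among these compounds, this is the first change that yields a direction, and it comes at a place on the ring that no earlier step touched, but the floor alone does not show a change beyond the scatter. Its true size stays open because compound 2 has only a limit, not a number: the limit of > 585000 nM in this assay, at which 1 of the 4 values shown sits.

From the compounds shown here alone, what other groups at this place, such as fluoro or an amine, would do remains open. So does whether chloro acts the same way in the ethyl ester, compound 1.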